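From a Dichlorophenyl Analogue to a Methylsulfanyl Analogue

The source may report more compounds than this note shows. Statements on the series, on what has been measured and on what is new or still open speak of the compounds shown alone.

Compound 1 `COc1cc(-n2ncnc2-c2ccc(OC(C)C)cc2)cc(OC)c1OC`: in a functional assay on A549 cells (Homo sapiens) for antiproliferative activity, read by MTT assay, with a stated time of 72 h (on this read-out lower numbers stand for stronger inhibition and higher numbers for weaker inhibition), compound 1 gives > 10000 nM, a limit of the assay.
Compound 2 `COc1cc(-n2ncnc2-c2ccc(C)cc2)cc(OC)c1OC`: compound 2 gives 1100 nM.
Compound 3 `COc1cc(-n2ncnc2-c2ccc(Cl)c(Cl)c2)cc(OC)c1OC`: compound 3 gives > 10000 nM, again a limit.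

Compound 3 therefore sits at the limit of > 10000 nM in this assay, at which 2 of the 3 values shown sit, and has no number of its own. Compound 4 `COc1cc(-n2ncnc2-c2ccc(SC)cc2)cc(OC)c1OC` differs from it in one place: 4-(methylsulfanyl)phenyl in place of 3,4-dichlorophenyl on an aromatic carbon. Among the compounds with values here, two measured steps bear on this change. an at least 9.0-fold higher number from compound 2 to compound 3 (0.95 log units; beyond the scatter) shows that replacing 4-methylphenyl by 3,4-dichlorophenyl weakened inhibition, while an at least 9.0-fold lower number from compound 1 to compound 2 (0.95 log units; beyond the scatter) shows that isopropoxy was also unfavourable compared with methyl. Methylsulfanyl returns to a single substituent on the phenyl ring, as in compound 2. The expected step is an at least 3.3-fold lower number from compound 3 to compound 4 (0.52 log units; beyond the scatter), a decrease in the number. Compound 4 is estimated at 3000 nM, within 700 nM to 12000 nM.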

Compound 4, half-maximal inhibitory concentration: 800 nM
Compound 4: the middle estimate sits 3.8-fold (0.57 log units) above what was measured; the range from low to high includes it.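

Methylsulfanyl gives much stronger inhibition than the two groups at the limit, with an at least 12-fold lower number from compound 3 to compound 4 (1.09 log units; beyond the scatter) and an at least 12-fold lower number from compound 1 to compound 4 (1.09 log units; beyond the scatter) as the steps, and both start from a limit of the assay, not a number: the limit of > 10000 nM in this assay, at which 2 of the 4 values shown sit.
Against methyl the change cannot be told apart, with a 1.4-fold lower number from compound 2 to compound 4 (0.14 log units; within the scatter) as the step.
Having one group on the phenyl ring is not enough in itself, as the isopropoxy group of compound 1 shows.

As far as these compounds go, how an amine, a carboxylic acid or a longer alkyl chain on this phenyl ring would behave remains open.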